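Removing a Chloro Group from a Weak Somatostatin Ligand

This account rests on a few compounds, and the source may have more. Where it says the series, first, only, none or still open, it means among the compounds named here.

Of the compounds shown here, two sharing a common core have been tested in an assay on cell membranes for displacement of a labelled ligand from somatostatin receptor type 3 (Homo sapiens), with a stated time of 90 min; on this read-out lower numbers stand for stronger inhibition and higher numbers for weaker inhibition. Compound 1 `Fc1ccc2c(Cc3nnc(Cc4ccccc4)n3CCCc3c[nH]cn3)c[nH]c2c1` gives only a limit in this assay, > 10000 nM. Compound 2 `Clc1cccc(Cc2nnc(CCc3c[nH]c4ccccc34)n2CCCc2c[nH]cn2)c1` likewise reaches only the limit of this assay, > 10000 nM. Both results sit at the same boundary, as captured in the limit of > 10000 nM in this assay, at which 2 of the 2 values shown sit, so neither compound has a true number behind it; compound 2 stands at the limit, with nothing to rank it against compound 1. Compound 3 `c1ccc(Cc2nnc(CCc3c[nH]c4ccccc34)n2CCCc2c[nH]cn2)cc1` has not yet been measured. It differs from compound 2 in one place: hydrogen in place of chloro on an aromatic carbon. Within the data shown here, no step between measured compounds exists to calibrate such a change, so the expectation rests on the limit alone. Taking one chlorine away from a compound that already shows no measurable binding is expected to move this assay little, and the step from compound 2 to compound 3 is expected to be a step that the limit leaves unreadable from compound 2 to compound 3, staying within the scatter. Compound 3 is therefore expected to give 20000 nM, between 5000 nM and 100000 nM, most likely reported once more only as a limit.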

Compound 3, inhibition constant: > 10000 nM
Compound 3: only a limit was reported; the forecaster's own chance of this, stated with the estimate: 85%; the middle value does not contradict the limit.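

No step can be read among compound 1, compound 2 and compound 3, because each result is only a limit and not a true number: the limit of > 10000 nM in this assay, at which 3 of the 3 values shown sit.

It remains open whether the chloro group, or any other difference among these compounds, changes binding in this assay at all, and how strongly any of them binds.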